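Carbamate substituent changes on the shared core

A few compounds are considered here, and "the series" means these few. Any claim that something is new, unique, unknown or untested is made for them only; others in the source may bear on it.

Two compounds of the series have numbers in a functional assay on isolated protein for inhibition of Glucose-dependent insulinotropic receptor (Rattus norvegicus), read by HTRF and cAMP accumulation; on this read-out higher numbers stand for an effect only at larger amounts of compound and lower numbers for an effect already at smaller amounts. Compound 1 `Cc1nc(S(C)(=O)=O)ccc1Oc1ncnc(OC2CCN(C(=O)OC(C)(C)C(F)(F)F)CC2)c1F` gives 47.2 nM in this assay. Going by the values given here, compound 2 `Cc1nc(S(C)(=O)=O)ccc1Oc1ncnc(OC2CCN(C(=O)OC(C)(C)C#N)CC2)c1F` gives 1320 nM, the highest of the two numbers; its nearest neighbour is compound 1, and the step of a 28-fold higher number from compound 1 to compound 2 (1.45 log units; beyond the scatter) is the only measured step so far.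

Compound 3 `Cc1nc(S(C)(=O)=O)ccc1Oc1ncnc(OC2CCN(C(=O)OC(C)F)CC2)c1F` is not yet measured. It differs from compound 2 in one place: 1-fluoroethyl in place of 1-cyano-1-methylethyl on an oxygen next to a carbonyl group. Among the compounds with values here, no measured step covers this exact exchange. Within the data shown here, the one step that bears on it, a 28-fold higher number from compound 1 to compound 2 (1.45 log units; beyond the scatter), shows that replacing a fluorine-bearing group by a nitrile at the carbamate oxygen raised the number strongly; compound 3 returns a fluorine to that position, though within a smaller group than in compound 1. A move back toward the lower number of compound 1 is therefore expected, but it is uncertain whether the full gain returns. For compound 3 the expected step is a 5.3-fold lower number from compound 2 to compound 3 (0.72 log units; beyond the scatter) in this assay. The estimate for compound 3 is 250 nM, within a range from 50 nM to 1200 nM.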

Compound 3, half-maximal effective concentration: 315 nM
Estimate against measurement, compound 3: 1.3-fold (0.10 log units) below; the measured number falls inside the stated range.
By their numbers in this assay, from the lowest: compound 1; then compound 3; then compound 2.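

In this assay, 1-fluoroethyl in place of 1-cyano-1-methylethyl on an oxygen next to a carbonyl group gives a 4.2-fold lower number from compound 2 to compound 3 (0.62 log units; beyond the scatter), so this position tolerates a change in which the nitrile leaves, a fluorine enters and the group becomes smaller, and the number of compound 2 is not a floor for small groups here. The same group in place of 1-methyl-1-(trifluoromethyl)ethyl gives a 6.7-fold higher number from compound 1 to compound 3 (0.82 log units; beyond the scatter), which places compound 3 between the other two and shows that a fluorine on this group does not by itself bring back the number of compound 1. The data on hand offer nothing that explains either step.

The compounds shown leave open whether the fluorine count, the branching of the chain or the overall size of the group accounts for these differences, since each exchange alters several of these at once. An unfluorinated ethyl or tert-butyl group on the same oxygen, or a 1,1-difluoroethyl group, would help to separate these features on the shared core.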